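Swapping iodo for acetyl on a CRF receptor ligand

The compounds below may be only part of what the source reports. "The series", "measured", "known", "first", "only" and "open" are said of these compounds alone.

Three compounds give a first picture. Compound 1 `CCN(CC)c1cc(C)nc(N(CC)c2ccc(C(C)=O)cc2Br)n1`, compound 2 `CCCN(CCC#N)c1nc(C)nc(N(CC)c2ccc(N(C)C)cc2C)n1` and compound 3 `CCCCN(CC)c1cc(C)nc(N(CC)c2ccc(I)cc2Br)n1` were all tested in an assay on isolated protein for binding affinity to corticotropin-releasing factor receptor 1 (Homo sapiens); a higher number here means a weaker inhibitor, a lower number a stronger inhibitor. Compound 1 gives 5 nM, compound 2 gives 7 nM and compound 3 gives 14 nM, the highest of the three numbers; its gap to compound 2 lies within the usual scatter, while its gap to compound 1 lies beyond it.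

Compound 4 `CCCCN(CC)c1cc(C)nc(N(CC)c2ccc(C(C)=O)cc2Br)n1` has not yet been measured. It differs from compound 3 in one place: acetyl in place of iodo on an aromatic carbon. Compound 1, which also carries an acetyl group, gives 5 nM in this assay, a lower number than compound 3. Going by the values given here, no measured pair shows this exact change on a shared scaffold, so the expectation rests on that comparison alone. The step of a 2.0-fold lower number from compound 3 to compound 4 (0.30 log units; within the scatter) is expected to be a modest drop in the number, possibly no larger than the scatter. Compound 4 is therefore estimated at 7 nM, within a range from 2.5 nM to 20 nM.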

Compound 4, inhibition constant: 8 nM
The estimate for compound 4 lay 1.1-fold (0.06 log units) below the measured number; the range from low to high includes it.
By their numbers in this assay, from the lowest: compounds 1, 2, 4 and 3 (each within the scatter of the next, the first and the last beyond it).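

The swap of iodo for acetyl can now be read on one shared scaffold: in this assay it gives a 1.8-fold lower number from compound 3 to compound 4 (0.24 log units; within the scatter), so on this aromatic carbon, the two groups cannot be told apart, although acetyl brings more heavy atoms and a hydrogen-bond acceptor. A second single change, ethyl in place of hydrogen on a saturated chain carbon, two bonds along the chain from a nitrogen on an aromatic ring, gives a 1.6-fold higher number from compound 1 to compound 4 (0.20 log units; within the scatter), so this chain change cannot be told from the scatter either. No measurement here offers an explanation for either step.

On these data alone, whether a carboxylic acid or a primary amide on this aromatic carbon would give a similar number remains open. So does the outcome of a longer chain on that nitrogen.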